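The compounds below may be only part of what the source reports. "The series", "measured", "known", "first", "only" and "open" are said of these compounds alone.

Compound 1 `COc1cc(NC(=O)Nc2cc(Nc3cccc(C(C)(C)C)c3)ncn2)cc(OC)c1`, 13.1%
Compound 2 `COc1cc(NC(=O)Nc2cc(Nc3ccc(F)c(Cl)c3)ncn2)cc(OC)c1`, 25.5%
Compound 3 `COc1cc(NC(=O)Nc2cc(Nc3cc(C(F)(F)F)ccc3OC)ncn2)cc(OC)c1`, 63%

All three values come from a functional assay on NCI-H520 cells (Homo sapiens) for inhibition, read by MTT assay, with a stated time of 48 h, tested at 10 uM; a higher number here means more inhibition at the concentration tested (going by the name of the read-out), a lower number less inhibition. Compound 3 stands highest of the three: compound 2 reads lower and compound 1 lower still, both gaps beyond the scatter. Compound 4 `COc1cc(NC(=O)Nc2cc(Nc3cc(I)ccc3OC)ncn2)cc(OC)c1` differs from compound 3 by iodo in place of trifluoromethyl on an aromatic carbon. Going by the values given here, the only measured step, a number 12.4 percentage points higher from compound 1 to compound 2 (beyond the scatter), exchanges the entire phenyl group on the nitrogen and so bears only loosely on a one-group swap; no step that changes a single group on the ring carrying the methoxy group has been measured. For compound 4 a small or modestly downward step is expected, a number 13 percentage points lower from compound 3 to compound 4 (beyond the scatter). Compound 4 is estimated at 50%, with a range from 25% to 72%.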

Compound 4, a percentage reported as inhibition, at one concentration (the size of the read-out at that concentration, not a potency): 55%
The estimate for compound 4 lay 5 percentage points below the measured number, within the range that was stated.
By their numbers in this assay, from the lowest: compound 1; then compound 2; then compounds 4 and 3 (each within the scatter of the next).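

In this assay, iodo in place of trifluoromethyl para to a methoxy group gives a number 8 percentage points lower from compound 3 to compound 4 (within the scatter), so the two groups cannot be told apart at this place. The larger exchanges give a number 29.5 percentage points higher from compound 2 to compound 4 (beyond the scatter) and a number 41.9 percentage points higher from compound 1 to compound 4 (beyond the scatter), but each replaces the entire phenyl group on the nitrogen and isolates no single substituent. No measurement at hand explains why iodo and trifluoromethyl read alike.

Open, from the compounds shown here alone, is whether an amine or a carboxylic acid on this aromatic carbon would hold the reading. Going by these compounds, the contribution of the methoxy group itself also remains open.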